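The compounds below may be only part of what the source reports. "The series", "measured", "known", "first", "only" and "open" are said of these compounds alone.

Of the compounds shown here, three sharing one core have been measured in an ADME assay on the whole organism with Oryza sativa as the target, tested at 0.1 uM; on this read-out lower numbers stand for a stronger effect and higher numbers for a weaker effect at the one concentration tested. Compound 1 `CCCc1ccc(NC(=O)N[C@@H](C)c2ccccc2)cc1` gives 97%, compound 2 `CCOC(=O)c1ccc(NC(=O)N[C@@H](C)c2ccccc2)cc1` gives 99%, and compound 3 `C[C@@H](NC(=O)Nc1ccc(F)cc1)c1ccccc1` gives 98%. Within the data shown here, the single step between neighbours, a number 2 percentage points higher from compound 1 to compound 2 (within the scatter), lies within the scatter. Compound 3 sits with its nearest number at compound 1 and its furthest at compound 2, both within the scatter, so the three numbers cannot be told apart. Compound 4 `C[C@H](NC(=O)Nc1ccc(F)cc1)c1ccccc1` differs from compound 3 only in configuration: the two compounds have the same atoms and bonds and differ only in configuration as drawn: 1 of 1 stereo elements differ; a stereocentre at a saturated chain carbon is drawn R in compound 3 and S in compound 4. Among the measured compounds shown here, no measured step alters a stereocentre, so none bears directly on this change; the three measured values simply sit close together. For compound 4 the expected step is therefore none beyond the scatter, a number 1 percentage points lower from compound 3 to compound 4 (within the scatter). Compound 4 is estimated at 97%, within a range from 88% to 100%.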

Compound 4, a percentage reported as activity, at one concentration (the size of the read-out at that concentration, not a potency): 96%
Beside the measured number, compound 4's estimate is 1 percentage points above it; measured number inside the range.
By their numbers in this assay, from the lowest: compounds 4, 1, 3 and 2 (each within the scatter of the next).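

Changing the stereocentre at the saturated chain carbon from R to S now has a direct test in this assay, and it gives a number 2 percentage points lower from compound 3 to compound 4 (within the scatter), so no effect of this change can be told from the scatter. This pair isolates a single change: the fact that compounds 3 and 4 differ only in the configuration as drawn. Fluoro in place of either other group on the aromatic carbon also stays within the scatter, with a number 3 percentage points lower from compound 2 to compound 4 (within the scatter) and a number 1 percentage points lower from compound 1 to compound 4 (within the scatter).

On these data alone, whether the stereocentre matters when propyl or ethoxycarbonyl sits on the aromatic carbon remains open. So does whether an amine or a carboxylic acid there would give a number clearly apart from these.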